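The source may report more compounds than this note shows. Statements on the series, on what has been measured and on what is new or still open speak of the compounds shown alone.

Working notes on the series. All three measured compounds share one core and differ only in the aryl group on the carbon with a double bond to nitrogen. In a functional assay on the whole organism (strain Wistar) for inhibition, with Rattus norvegicus as the target, read by paw edema, with a stated time of 3 h, at a dose of 10 mg/kg by the intraperitoneal route (on this read-out lower numbers stand for less inhibition and higher numbers for more inhibition at the one dose given (going by the name of the read-out)), compound 1 `O=C(N/N=C/c1ccccc1)c1cccnc1Nc1cccc(C(F)(F)F)c1` gives 21.2%. Compound 2 `O=C(N/N=C/c1ccc(O)c(O)c1)c1cccnc1Nc1cccc(C(F)(F)F)c1` gives 38.2%, and compound 3 `COc1cc(/C=N/NC(=O)c2cccnc2Nc2cccc(C(F)(F)F)c2)cc(OC)c1OC` gives 28.5%. For the measured compounds named here, compound 2 holds the highest of the three numbers; its gap to compound 3 lies within the scatter, while its gap to compound 1 is the one measured step, a number 17 percentage points higher from compound 1 to compound 2 (beyond the scatter), which is modest but beyond the scatter.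

Compound 4 `O=C(N/N=C/c1cccnc1)c1cccnc1Nc1cccc(C(F)(F)F)c1` has not been measured. Relative to compound 2 the change is pyridin-3-yl in place of 3,4-dihydroxyphenyl on a carbon with a double bond to nitrogen. Going by the values given here, the only step that bears on this is the one from compound 1 to compound 2, where adding the two hydroxyl groups to phenyl raised the read-out; compound 4 gives those hydroxyl groups up, so a step back toward the number of compound 1 is expected, although no step to pyridin-3-yl itself has been measured. The expected step is a number 12.2 percentage points lower from compound 2 to compound 4 (beyond the scatter). Compound 4 is thus estimated at 26%, with a range from 14% to 38%.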

Compound 4, a percentage reported as inhibition, in the whole organism at one dose (the size of the read-out at that dose, not a potency): 52.4%
The estimate for compound 4 lay 26.4 percentage points below the measured number; measured number outside the range, above it.
By their numbers in this assay, from the lowest: compounds 1, 3 and 2 (each within the scatter of the next, the first and the last beyond it); then compound 4.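

At this position on the carbon with a double bond to nitrogen, pyridin-3-yl gives a number 14.2 percentage points higher from compound 2 to compound 4 (beyond the scatter) in this assay, so the two hydroxyl groups of the 3,4-dihydroxyphenyl group are not needed for a higher number among these compounds. Pyridin-3-yl in place of phenyl gives a number 31.2 percentage points higher from compound 1 to compound 4 (beyond the scatter), the largest listed step so far, which moves the attention from hydroxyl substitution to the ring with a hetero atom, a ring that has no hydrogen-bond donors. No supporting measurement bears on why the number rises with this change.

Whether the ring nitrogen must sit as in pyridin-3-yl stays open, as the compounds shown include neither pyridin-2-yl nor pyridin-4-yl. Also open, from the compounds shown here alone, is how a 4-hydroxyphenyl or a 4-(dimethylamino)phenyl group would read at this position.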